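The source may hold more compounds than are shown below. What is called first, only, known or untested is meant among the compounds shown, and "the series" means these compounds.

Measured compounds and their results:

Compound 1, `CCN(Cc1ccccc1)Cc1ccc(CN2CCc3ccc(OS(N)(=O)=O)cc3C2)cc1`, gives 1%.
Compound 2, `CCN(Cc1cccc(Br)c1)c1cccc(C(=O)N2CCc3ccc(OS(N)(=O)=O)cc3C2)c1`, gives 20.9%.
Compound 3, `CCCN(Cc1ccccc1)c1ccc(C(=O)N2CCc3ccc(OS(N)(=O)=O)cc3C2)cc1`, gives 64.8%.

In an assay on HEK293 cells for inhibition of Steryl-sulfatase (Homo sapiens), tested at 0.1 uM (on this read-out lower numbers stand for a weaker effect and higher numbers for a stronger effect at the one concentration tested), compound 2 stands second highest of the three numbers. Its nearest neighbour is compound 1, whose number is lower by a margin beyond the usual scatter of this kind of measurement. The furthest is compound 3, whose number is higher, again beyond the scatter. Compound 2 therefore sits in the middle of the range these three compounds span, clearly above compound 1 and clearly below compound 3.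

The next compound, compound 4, `CN(CCN1CCCCC1)c1cccc(C(=O)N2CCc3ccc(OS(N)(=O)=O)cc3C2)c1`, keeps the shared core of compound 2 and changes only the substituent on the aromatic ring of the benzamide portion: methyl(2-(piperidin-1-yl)ethyl)amino in place of (3-bromobenzyl)(ethyl)amino on an aromatic carbon. Going by the values given here, no measured pair in this set shows this kind of change, so its effect is unknown from the data and can only be estimated from where compound 2 stands. The study expects the step of a number 4.1 percentage points higher from compound 2 to compound 4 (within the scatter) to be small, with no clear direction beyond the scatter. Compound 4 is therefore estimated at 25%, within a range from 5% to 55%, reflecting the wide uncertainty of a change without precedent among the measured compounds.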

Compound 4, a percentage reported as inhibition, at one concentration (the size of the read-out at that concentration, not a potency): 24.5%
Estimate against measurement, compound 4: 0.5 percentage points above, within the range that was stated.
By their numbers in this assay, from the lowest: compound 1; then compounds 2 and 4 (each within the scatter of the next); then compound 3.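

In this assay, going by these compounds alone, putting methyl(2-(piperidin-1-yl)ethyl)amino in place of (3-bromobenzyl)(ethyl)amino on an aromatic carbon, meta to a large group, gives the first step that can be read at this position, a number 3.6 percentage points higher from compound 2 to compound 4 (within the scatter), and so the read-out does not separate these two substituents. The exchange is a substantial one: the six-membered aromatic ring of carbon only and the bromine leave, while a six-membered non-aromatic ring with 1 hetero atom and a second nitrogen enter, yet the number stays within the scatter at this single concentration. Nothing available bears on why such different substituents read alike.

The compounds shown leave open whether this tolerance extends to other kinds of group at the same aromatic carbon, such as a carboxylic acid or a morpholine ring in place of the piperidine. They also leave open whether a longer chain between the two nitrogens would move the number beyond the scatter, in either direction.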